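A few compounds are considered here, and "the series" means these few. Any claim that something is new, unique, unknown or untested is made for them only; others in the source may bear on it.

Compound 2 `COc1cc2nc(-c3ccc(-n4c(C)ccc4-c4ccc(F)cc4)cc3)sc2c(OC)c1OC` stands at 2670 nM in a functional assay on MCF7 cells (Homo sapiens) for cytotoxicity, read by sulforhodamine B assay, with a stated time of 48 h (on this read-out lower numbers stand for stronger inhibition of growth and higher numbers for weaker inhibition of growth), and compound 1 `COc1cc2nc(-c3ccc(-n4c(C)ccc4-c4ccc(C)cc4)cc3)sc2c(OC)c1OC` stands at 2910 nM, the two numbers lying within the usual scatter of each other. Compound 3 `COc1ccc(-c2ccc(C)n2-c2ccc(-c3nc4cc(OC)c(OC)c(OC)c4s3)cc2)cc1` carries methoxy in place of fluoro on an aromatic carbon. Among the measured compounds shown here, one measured step bears on this place: a 1.1-fold lower number from compound 1 to compound 2 (0.04 log units; within the scatter). That exchange left the number essentially unchanged, so the exchange of fluoro for methoxy is expected to behave alike, giving a 1.0-fold higher number from compound 2 to compound 3 (0.00 log units; within the scatter) with no movement beyond the scatter. Compound 3 is therefore estimated at 2700 nM, with a range from 1200 nM to 6000 nM.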

Compound 3, concentration for 50% growth inhibition: 1230 nM
Estimate against measurement, compound 3: 2.2-fold (0.34 log units) above; low and high end bracket the measured number.
By their numbers in this assay, from the lowest: compound 3; then compounds 2 and 1 (each within the scatter of the next).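

In this assay the group para to a large group does matter: methoxy in place of fluoro gives a 2.2-fold lower number from compound 2 to compound 3 (0.34 log units; beyond the scatter) and methoxy in place of methyl gives a 2.4-fold lower number from compound 1 to compound 3 (0.37 log units; beyond the scatter), so this position is not indifferent to every exchange. Methoxy stands apart here from fluoro and methyl, which had stayed within the scatter of each other. Nothing measured here explains that difference.

As far as these compounds go, whether a hydroxyl, an amine or a longer chain such as ethoxy at this position would lower the number further stays open. So does whether methoxy would act alike elsewhere on this ring.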